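Shifting a halogen on the benzyl group of compound 3

The source may hold more compounds than are shown below. What is called first, only, known or untested is meant among the compounds shown, and "the series" means these compounds.

Measured compounds:
compound 1 `COC(=O)C(c1ccccc1Cl)N1CCC(O)(Cn2cnc3c(cnn3-c3ccc(F)cc3)c2=O)CC1`: "not determined" (no result reported)
compound 2 `O=c1c2cnn(-c3ccc(F)cc3)c2ncn1CC1(O)CCN(Cc2cccc(Cl)c2)CC1`: "not determined" (no result reported)
compound 3 `O=c1c2cnn(-c3ccc(F)cc3)c2ncn1CC1(O)CCN(Cc2ccc(Cl)cc2)CC1`: 8000 nM

Three compounds share one core and differ in the group on the saturated chain carbon bound to the amine nitrogen in the ring. For compound 1 `COC(=O)C(c1ccccc1Cl)N1CCC(O)(Cn2cnc3c(cnn3-c3ccc(F)cc3)c2=O)CC1` and compound 2 `O=c1c2cnn(-c3ccc(F)cc3)c2ncn1CC1(O)CCN(Cc2cccc(Cl)c2)CC1` no result was reported in an assay on Sf21 cells for inhibition of ubiquitin carboxyl-terminal hydrolase 7 (Homo sapiens), read by spectrophotometry, with stated times of 30 min and 2 h; a lower number here means a stronger inhibitor, a higher number a weaker inhibitor. Among the measured compounds shown here, compound 3 `O=c1c2cnn(-c3ccc(F)cc3)c2ncn1CC1(O)CCN(Cc2ccc(Cl)cc2)CC1` is therefore the only compound with a number in this assay, where compound 3 gives 8000 nM; it stands alone, with nothing beside it to rank it against.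

Compound 4 `O=c1c2cnn(-c3ccc(F)cc3)c2ncn1CC1(O)CCN(Cc2ccccc2Br)CC1` is the next step. Its change from compound 3 is 2-bromophenyl in place of 4-chlorophenyl on a saturated chain carbon bound to an amine nitrogen in a ring. For the measured compounds named here, no step between two measured compounds is available to set the size of this change, and the two entries without a number give no direction either. With a single weak starting value and no comparator, the expectation is a small step at most, in either direction, or none beyond the scatter.

On that basis compound 4 is estimated at 10000 nM in this assay, within a range from 3000 nM to 40000 nM. The expected step from compound 3 to compound 4 is a 1.3-fold higher number from compound 3 to compound 4 (0.10 log units; within the scatter).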

Compound 4, half-maximal inhibitory concentration: 3100 nM
Compound 4: middle estimate off by 3.2-fold (0.51 log units), on the high side; the range from low to high includes it.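

In this assay, the change from 4-chlorophenyl to 2-bromophenyl on a saturated chain carbon bound to an amine nitrogen in a ring gives a 2.6-fold lower number from compound 3 to compound 4 (0.41 log units; beyond the scatter), the first measured size for a change at this position; the step is modest but lies beyond the scatter. The swap replaces chlorine with bromine and also moves the halogen on the ring, so this single step cannot assign the difference to either part of the change. No supporting evidence bears on the result, so the measurements show only its size and direction, not its cause.

Among the compounds shown here, compound 1 and compound 2 have no reported result, so no step to either of them can be read, and the shift in the position of the chlorine remains without a number. The compounds shown leave open how 2-chlorophenyl or 4-bromophenyl would compare, since either would separate the halogen from its place on the ring, and whether an unsubstituted phenyl, a methoxy group or a carboxylic acid on the ring would move the value further.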